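The source may report more compounds than this note shows. Statements on the series, on what has been measured and on what is new or still open speak of the compounds shown alone.

Measured compounds in an assay for inhibition of Nicotinamide phosphoribosyltransferase (Mus musculus), read by fluorescence, with a stated time of 1 h, in the presence of a further agent that is not named here; on this read-out lower numbers stand for stronger inhibition and higher numbers for weaker inhibition:
compound 1 `NC(=O)c1ccccc1-c1ccccc1C(=O)NCCCCCCCn1cc(-c2cccnc2)nn1` gives 87.9 nM
compound 2 `O=C(NCCCCCCCn1cc(-c2cccnc2)nn1)c1ccccc1-c1cccnc1` gives 28.5 nM

Compound 2 holds the lowest of the two numbers in this assay. Within the data shown here, the only measured step is a 3.1-fold lower number from compound 1 to compound 2 (0.49 log units; beyond the scatter), a modest change that lies beyond the scatter.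

Compound 3 `O=C(NCCCCCCCn1cc(-c2cccnc2)nn1)c1ccccc1-c1c[nH]nn1` is not yet measured. Its change from compound 2 is 1H-1,2,3-triazol-4-yl in place of pyridin-3-yl on an aromatic carbon. The step from compound 1 to compound 2 is the only one that touches this position; it shows that exchanging the group there can move the number beyond the scatter, but it does not show the direction for a five-membered ring with three hetero atoms and one hydrogen-bond donor entering in place of pyridin-3-yl. Among the measured compounds shown here, no measured step bears directly on that exchange.

The expectation for compound 3 is therefore a 1.8-fold higher number from compound 2 to compound 3 (0.24 log units; within the scatter), a shift within or near the scatter, with the direction uncertain. Compound 3 is estimated at 50 nM in this assay, with a range from 15 nM to 200 nM.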

Compound 3, half-maximal inhibitory concentration: 42.5 nM
The estimate for compound 3 lay 1.2-fold (0.07 log units) above the measured number, within the range that was stated.
By their numbers in this assay, from the lowest: compounds 2 and 3 (each within the scatter of the next); then compound 1.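

In this assay the exchange gives a 1.5-fold higher number from compound 2 to compound 3 (0.17 log units; within the scatter) and so, on this aromatic carbon, a five-membered aromatic ring with a hydrogen-bond donor is not separated from a six-membered one without a donor. The exchange from the carbamoylphenyl compound gives a 2.1-fold lower number from compound 1 to compound 3 (0.32 log units; beyond the scatter) and thus places a second heteroaromatic group beyond the scatter from 2-carbamoylphenyl, in the same direction as pyridin-3-yl. No measured information here accounts for these numbers.

The compounds shown leave open whether a carboxylic acid or an amine on this aromatic carbon would keep the number in the same region. They also leave open whether a methyl group on the triazole nitrogen would do so, and whether a longer chain would alter the picture.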